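The source may hold more compounds than are shown below. What is called first, only, known or untested is meant among the compounds shown, and "the series" means these compounds.

The measured compounds:
compound 1 `O=C(NC(=S)NNc1ncnc2ccccc12)c1ccc(F)cc1`, which in a functional assay on CNE-2 cells (Homo sapiens) for cytotoxicity, read by MTT assay, with a stated time of 72 h (a lower number here means a stronger inhibitor, a higher number a weaker inhibitor), gives 2840 nM;
compound 2 `COc1cc2ncnc(NNC(=S)NC(=O)c3ccc(C(F)(F)F)cc3)c2cc1OC`, which in this assay gives 16500 nM;
compound 3 `COc1cc2ncnc(NNC(=S)NC(=O)c3cccc(Cl)c3)c2cc1OC`, which in this assay gives 7460 nM.

Compound 1 stands lowest of the three numbers in this assay. Its nearest neighbour is compound 3, whose number is higher by a margin beyond the scatter, and compound 2 lies further off still. Compound 2 and compound 3 share a core that is not the core of compound 1, so the comparison across all three does not rest on a single change.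

Compound 4 `Cc1ccccc1C(=O)NC(=S)NNc1ncnc2ccccc12` has not yet been measured. Against compound 1 the change is 2-methylphenyl in place of 4-fluorophenyl on a carbonyl carbon. Among the measured compounds shown here, one measured step bears on it: a 2.2-fold lower number from compound 2 to compound 3 (0.34 log units; beyond the scatter), which also alters the aryl group on the carbonyl carbon, though on the other core. That step was modest. For the measured compounds named here, no measured pair sets a 2-methylphenyl against a 4-fluorophenyl, so the direction of the present change is open. A step of similar or smaller size is therefore expected for compound 4, in either direction, and most likely not far beyond the scatter. The expected number for compound 4 in this assay is 3500 nM, within 1500 nM to 8000 nM. This estimate corresponds to an expected step of a 1.2-fold higher number from compound 1 to compound 4 (0.09 log units; within the scatter).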

Compound 4, half-maximal inhibitory concentration: 5460 nM
Beside the measured number, compound 4's estimate is 1.6-fold (0.19 log units) below it; the range from low to high includes it.
By their numbers in this assay, from the lowest: compounds 1, 4 and 3 (each within the scatter of the next, the first and the last beyond it); then compound 2.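

In this assay, the aryl group on the carbonyl carbon can now be read on a second core, and 2-methylphenyl in place of 4-fluorophenyl gives a 1.9-fold higher number from compound 1 to compound 4 (0.28 log units; within the scatter). Unlike the step measured on the other core, this one does not separate the two compounds, so on this core the two aryl groups, each with the same count of heavy atoms, cannot be told apart by their numbers in this cytotoxicity read-out. No supporting measurement accompanies this result, so it offers no explanation of it.

The change alters both the substituent and its printed ring position at once, so a 2-fluorophenyl or a 4-methylphenyl group would be needed to tell the two apart on this core. How far this position stretches also remains open, since every group shown there is a substituted phenyl ring, and neither an unsubstituted phenyl, a phenyl bearing an amine or a carboxylic acid, nor a saturated cyclohexyl ring or a longer alkyl chain appears among these compounds.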